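Chain extension on the chloro analogue in the oxide synthase assay

A few compounds are considered here, and "the series" means these few. Any claim that something is new, unique, unknown or untested is made for them only; others in the source may bear on it.

Measured so far:
compound 1 `CCCCC(=O)N1N=C(c2cc(OC)ccc2N)SC1(C)C` with 101%
compound 2 `CCC(=O)N1N=C(c2cc(Cl)ccc2N)SC1(C)C` with 1.07%

Two compounds have been examined in an assay on isolated protein for inhibition of Nitric oxide synthase, inducible (Homo sapiens), read by scintillation counting, with a stated time of 30 min, tested at 50 uM; on this read-out higher numbers stand for more inhibition at the one concentration tested (going by the name of the read-out) and lower numbers for less inhibition. Compound 1 gives 101% in this assay, and compound 2 gives 1.07%. Compound 2 therefore stands lowest of the two numbers; its nearest neighbour is compound 1, whose value lies higher by a margin beyond the usual scatter. Among the measured compounds shown here, the two compounds differ in more than one place, so no single step connects them, and only their two values can be compared.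

Compound 3 `CCCCC(=O)N1N=C(c2cc(Cl)ccc2N)SC1(C)C` has not yet been measured. It differs from compound 2 by ethyl in place of hydrogen on a saturated chain carbon, two bonds along the chain from a carbonyl carbon. For the measured compounds named here, no step of this kind has been measured among the compounds, so its size is open. Because compound 1 with its longer chain shows 101%, a move upward from compound 2 is expected for compound 3, though the other difference between compounds 1 and 2 cannot be separated out. Compound 3 is estimated at 45%, with a range of 5% to 95%, which means an expected step of a number 43.9 percentage points higher from compound 2 to compound 3 (beyond the scatter).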

Compound 3, a percentage reported as inhibition, at one concentration (the size of the read-out at that concentration, not a potency): 12.6%
Compound 3: the middle estimate sits 32.4 percentage points above what was measured; the range from low to high includes it.
By their numbers in this assay, from the lowest: compound 2; then compound 3; then compound 1.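

In this assay, ethyl in place of hydrogen on a saturated chain carbon, two bonds along the chain from a carbonyl carbon, gives a number 11.5 percentage points higher from compound 2 to compound 3 (beyond the scatter) with chloro held on the aromatic carbon, so this chain extension raises the number only modestly. With that chain held constant, chloro in place of methoxy on an aromatic carbon gives a number 88.4 percentage points lower from compound 1 to compound 3 (beyond the scatter) and is the large step. The wide difference between compound 1 and compound 2 could not be divided before, but of these two single changes the aromatic one now has the larger step, and no measurement shown here explains the size of either step.

The compounds shown leave open whether ethyl in place of hydrogen would give a step of similar size with methoxy on the aromatic carbon. From the compounds shown here alone, it also remains open how a longer chain in place of the butylcarbonyl group, or a fluoro or nitrile group on the aromatic carbon in place of chloro, would read in this assay.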